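A few compounds are considered here, and "the series" means these few. Any claim that something is new, unique, unknown or untested is made for them only; others in the source may bear on it.

In a functional assay on HepG2 cells (Homo sapiens) for cytotoxicity, with a stated time of 24 h (a higher number here means a weaker inhibitor, a lower number a stronger inhibitor), compound 2 `O=C(N/N=C/c1cc(I)cc(I)c1O)c1ccc(O)cc1` gives 19200 nM. Among the compounds with values here, that is the only plain number among the two values measured here. Compound 1 `Cc1ccc(C(=O)N/N=C/c2cc(I)cc(I)c2O)cc1` reaches only the limit of the assay, > 25000 nM. Putting a hydroxy group in place of a methyl group on the aromatic carbon gave the step of an at least 1.3-fold lower number from compound 1 to compound 2 (0.11 log units; that floor lies within the scatter); its size is known only as a floor because the limit of > 25000 nM in this assay, at which 1 of the 2 values shown sits, caps what can be read for compound 1. Compound 3 `O=C(N/N=C/c1cc(I)cc(I)c1O)c1ccc(F)cc1` carries yet another group at the same place: fluoro in place of hydroxy on an aromatic carbon. Within the data shown here, the one measured step that bears on this change is the one just described, and it was small, with a floor that lies within the scatter. Taking the hydroxy group away again, now for fluoro, which brings no hydrogen-bond donor and no acceptor, is therefore expected to push the number back upward by an estimated step of a 1.3-fold higher number from compound 2 to compound 3 (0.11 log units; within the scatter), a modest rise that sits partly within the scatter. Compound 3 is thus expected to give about 25000 nM, with a range from 12000 nM to 60000 nM, and a fair chance that only a limit is reported.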

Compound 3, half-maximal inhibitory concentration: 12100 nM
Estimate against measurement, compound 3: 2.1-fold (0.32 log units) above; the range from low to high includes it.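

At this place on the ring, para to a large group, the new result shows that the hydrogen-bond donor and acceptor of hydroxy are not needed for the activity seen in this assay: exchanging hydroxy for fluoro gives a 1.6-fold lower number from compound 2 to compound 3 (0.20 log units; within the scatter), so these two compounds cannot be told apart. Within the data shown here, the comparison of fluoro with methyl is the first at this position to clear the usual scatter, with an at least 2.0-fold lower number from compound 1 to compound 3 (0.31 log units; beyond the scatter), which shows that the group here can matter, though only modestly so far. Compound 1 stands at a limit and not at a plain number, so this step is only a floor and its true size may be larger: the limit of > 25000 nM in this assay, at which 1 of the 3 values shown sits.

Going by these compounds, how far fluoro and methyl really lie apart stays open, as does the question of whether the order seen here is more than a small difference among three closely related groups. Also open, on these data alone, is what an amine, a carboxylic acid or a longer chain such as propyl would do at this same place on the otherwise unchanged core.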